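This account rests on a few compounds, and the source may have more. Where it says the series, first, only, none or still open, it means among the compounds named here.

Of the compounds shown here, three of a shared core have been tested in a functional assay on A549 cells (Homo sapiens) for cytotoxicity, with a stated time of 48 h; on this read-out higher numbers stand for weaker inhibition and lower numbers for stronger inhibition. Compound 1, `CC(C)C(=O)Oc1ccc2oc(/C=C/[S+](C)[O-])cc(=O)c2c1`, gives 2400 nM in this assay. Compound 2, `Cc1c(/C=C/[S+](C)[O-])oc2ccccc2c1=O`, gives 1500 nM, and compound 3, `COc1ccc2c(=O)cc(/C=C/[S+](C)[O-])oc2c1`, gives 2200 nM. Compound 1 gives the highest of the three numbers, but its gaps to compound 3 and to compound 2 both lie within the usual scatter of repeated measurements, so the three cannot be ordered against one another on these data.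

Compound 4, `CCCC(=O)Oc1ccc2oc(/C=C/[S+](C)[O-])cc(=O)c2c1`, has not yet been measured. It differs from compound 1 in one place: propyl in place of isopropyl on a carbonyl carbon. The two compounds contain the same atoms, joined differently; the group that leaves and the group that enters are of the same size and carry no donors, acceptors or charge.

Among the compounds with values here, no step between measured compounds tells how such a change has played out in this assay. On that basis the step from compound 1 to compound 4 is expected to be small, no change at the digits printed from compound 1 to compound 4 (within the scatter), with no direction beyond the scatter. Compound 4 is therefore estimated at 2400 nM, within a range from 1200 nM to 4800 nM.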

Compound 4, half-maximal inhibitory concentration: 2200 nM
Beside the measured number, compound 4's estimate is 1.1-fold (0.04 log units) above it, and the stated range covers the measured number.
By their numbers in this assay, from the lowest: compounds 2, 3, 4 and 1 (each within the scatter of the next).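

Within the data shown here, replacing isopropyl with propyl on a carbonyl carbon gives a 1.1-fold lower number from compound 1 to compound 4 (0.04 log units; within the scatter) in this assay, the first step at this position that can be read. For this pair, the rearrangement of the same atoms within the chain therefore produces no change that can be told apart from the usual scatter of repeated measurements. No supporting measurement here explains why the two chains give matching results.

From the compounds shown here alone, it remains open whether a longer chain such as pentyl, a ring such as phenyl, or an amine on this carbonyl carbon would also leave the read-out within the scatter. A single pair also cannot show whether isopropyl and propyl would match again on a different core.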